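Compound 2 Loses Its Acetyl Group

The compounds below may be only part of what the source reports. "The series", "measured", "known", "first", "only" and "open" are said of these compounds alone.

In a functional assay on HL-60 cells (Homo sapiens) for antiproliferative activity, read by XTT assay, with a stated time of 72 h (on this read-out higher numbers stand for weaker inhibition and lower numbers for stronger inhibition), two compounds have been measured so far. Compound 1 (`C=C(C)CCC[C@]1(C)C2=CCC[C@](C)(CC(=O)c3ccoc3)[C@H]2CC[C@H]1C`) reaches only a limit (> 100000 nM) and gives no actual number. Going by the values given here, compound 2 (`C=C(C)CCC[C@]1(C)C2=CCC[C@](C)(C[C@@H](OC(C)=O)C3=CC(=O)OC3O)[C@H]2CC[C@H]1C`) gives 3200 nM as the only actual number, so it stands alone as a measured reference point, with no second number to set it against.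

Compound 3 (`C=C(C)CCC[C@]1(C)C2=CCC[C@](C)(C[C@@H](O)C3=CC(=O)OC3O)[C@H]2CC[C@H]1C`) carries a single change from compound 2: hydrogen in place of acetyl on an oxygen on a saturated carbon, which turns acetoxy to hydroxy. Among the compounds with values here, no measured pair shows what such a change does, so the expectation rests on compound 2 alone, at 3200 nM on this scale. The estimated shift (a 1.4-fold higher number from compound 2 to compound 3 (0.15 log units; within the scatter)) is expected to stay within the usual scatter in this assay, with at most a slight weakening, though the lack of any measured step keeps the range wide. In this assay compound 3 is estimated at 4500 nM (expected range 1000 nM to 20000 nM).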

Compound 3, half-maximal inhibitory concentration: 3200 nM
Compound 3: the middle estimate sits 1.4-fold (0.15 log units) above what was measured, and the stated range covers the measured number.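

In this assay, going by these compounds alone, acetoxy gives way to hydroxy on this saturated carbon with no readable shift (no change at the digits printed from compound 2 to compound 3 (within the scatter)), so the first measured step at this place shows that the acetyl is not needed to keep the activity of compound 2. The large step lies elsewhere (an at least 31-fold lower number from compound 1 to compound 3 (1.49 log units; beyond the scatter)): it comes with the group of 9 heavy atoms, which holds the five-membered non-aromatic ring, in place of the group of 7 heavy atoms, which holds the five-membered aromatic ring, on a saturated chain carbon bound to a saturated ring carbon. Compound 1 gives only a limit and no number, so the true size of that step stays unknown: the limit of > 100000 nM in this assay, at which 1 of the 3 values shown sits.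

The compounds shown leave open whether this oxygen can itself be replaced, for example by a methoxy group or an amine, or whether a longer ester such as a benzoate would behave as the acetate does. They also leave open which part of the group of 9 heavy atoms accounts for the large step.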